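The compounds below may be only part of what the source reports. "The series", "measured", "known", "first", "only" and "open" are said of these compounds alone.

Compound 1 `COc1cc2sn(CCCN(C)Cc3ccccc3)c(=O)c2cc1OC`: 44.4%
Compound 2 `COc1ccccc1CN(C)CCCn1sc2cc(OC)c(OC)cc2c1=O`: 48.6%
Compound 3 `CCN(CCCn1sc2cc(OC)c(OC)cc2c1=O)Cc1ccccc1OC`: 37%

These three compounds share one core and were all tested in an assay on isolated protein for inhibition of Amine oxidase [flavin-containing] B (Homo sapiens), read by fluorescence, with a stated time of 30 min, tested at 10 uM; a lower number here means less inhibition, a higher number more inhibition at the concentration tested (going by the name of the read-out). Compound 3 gives the lowest of the three numbers; compound 1 lies close to it, within the scatter, while compound 2 sits higher by a margin beyond it, as the step of a number 11.6 percentage points lower from compound 2 to compound 3 (beyond the scatter) shows.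

Compound 4 `CCN(CCCn1sc2cc(OC)c(OC)cc2c1=O)Cc1ccc(N(C)C)cc1` has not been measured. It differs from compound 3 in one place: 4-(dimethylamino)phenyl in place of 2-methoxyphenyl on a saturated chain carbon bound to an amine nitrogen. Within the data shown here, the only measured step that touches the same benzyl ring is a number 4.2 percentage points higher from compound 1 to compound 2 (within the scatter), which stayed within the scatter. Among the measured compounds shown here, no measured step exchanges one ring substituent for another, so the change in compound 4 has no direct precedent here. The other step, a number 11.6 percentage points lower from compound 2 to compound 3 (beyond the scatter), concerns the chain on the amine, which compound 4 keeps unchanged from compound 3.

For the measured compounds named here, since the one ring change seen made no difference beyond the scatter, compound 4 is expected to stay near compound 3, with a number 2 percentage points higher from compound 3 to compound 4 (within the scatter) expected to be small. The estimate for compound 4 is 39%, in a range from 24% to 54%.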

Compound 4, a percentage reported as inhibition, at one concentration (the size of the read-out at that concentration, not a potency): 40.1%
Compound 4: the middle estimate sits 1.1 percentage points below what was measured; the measured number falls inside the stated range.
By their numbers in this assay, from the lowest: compounds 3, 4, 1 and 2 (each within the scatter of the next, the first and the last beyond it).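

In this assay, among these compounds, exchanging 2-methoxyphenyl for 4-(dimethylamino)phenyl gives a number 3.1 percentage points higher from compound 3 to compound 4 (within the scatter), so this is the first look at one ring substituent replaced by a different one rather than added to a bare ring. Both ring changes now shown stay within the scatter, while the only step beyond it among the steps shown remains the change in the chain on the amine. Nothing available explains why this exchange leaves the reading within the scatter.

As far as these compounds go, the effect of a carboxylic acid or a nitrile on this ring remains open, as does that of a pyridine ring in place of the benzene ring. From the compounds shown here alone, it is also open whether 4-(dimethylamino)phenyl would give a similar reading with the shorter methyl group on the amine, as in compound 2.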